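The source may hold more compounds than are shown below. What is called first, only, known or untested is meant among the compounds shown, and "the series" means these compounds.

Compound 1 `COc1ccc(NC(=O)c2cc(=O)[nH]c3cc(Br)ccc23)cc1` gives > 20000 nM in a functional assay on KYSE-410 cells (Homo sapiens) for antiproliferative activity, read by MTT assay, with a stated time of 72 h; on this read-out higher numbers stand for weaker inhibition and lower numbers for stronger inhibition.
Compound 2 `O=C(Nc1cc(F)cc(F)c1)c1cc(=O)[nH]c2cc(Br)ccc12` gives 11200 nM in this assay.
Compound 3 `O=C(Nc1cccc(F)c1)c1cc(=O)[nH]c2cc(-c3ccccc3F)ccc12` gives > 20000 nM in this assay.

The value for compound 3 in this assay is a limit of the assay rather than a number. The same holds for compound 1, whose value is also a limit. Thus (the limit of > 20000 nM in this assay, at which 2 of the 3 values shown sit), and compound 2 alone returns a measured number, which is itself weak. Compound 3 therefore stands among the weakest of the three, with nothing in the series below the limit by more than the scatter.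

Compound 4 `C#Cc1ccc2c(C(=O)Nc3cccc(F)c3)cc(=O)[nH]c2c1` is the unmeasured partner of compound 3. It carries ethynyl in place of 2-fluorophenyl on an aromatic carbon. Going by the values given here, no measured pair in this set shares this change, so its size is unknown. Given that compound 3 sits at the limit with > 20000 nM, compound 4 is expected to show a step of an at least 1.4-fold lower number from compound 3 to compound 4 (0.15 log units; that floor lies within the scatter) in this assay, in the direction of modestly stronger inhibition but likely still weak. Compound 4 is estimated at 14000 nM, within a range from 4000 nM to 30000 nM.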

Compound 4, half-maximal inhibitory concentration: 9700 nM
Beside the measured number, compound 4's estimate is 1.4-fold (0.16 log units) above it; measured number inside the range.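

In this assay, going by these compounds alone, the change on this aromatic carbon gives the first step that can be read, an at least 2.0-fold lower number from compound 3 to compound 4 (0.31 log units; beyond the scatter), with ethynyl in place of 2-fluorophenyl, so this position can move the read-out. Compound 3 gives > 20000 nM, which is a limit of the assay. The step is a floor and its full size stays unknown, because one of its two ends rests on that limit: the limit of > 20000 nM in this assay, at which 2 of the 4 values shown sit.

This single pair cannot tell whether the step goes with the loss of the aromatic ring or with the entering triple bond. Going by these compounds, how a primary amine, a carboxylic acid or an ethyl chain would read on the same aromatic carbon also stays open.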